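This account rests on a few compounds, and the source may have more. Where it says the series, first, only, none or still open, it means among the compounds named here.

Compound 1, `C[S+]([O-])c1c(F)c(N)c2c(=O)cc(-c3ccc(N)c(F)c3)oc2c1F`, in a functional assay on HeLa cells (Homo sapiens) for cytotoxicity, read by neutral red uptake, with a stated time of 3 days (a lower number here means a stronger inhibitor, a higher number a weaker inhibitor), gives only a limit: > 100000 nM.
Compound 2, `CCOC(=O)c1c(F)c(N)c2c(=O)cc(-c3ccc(N)c(F)c3)oc2c1F`, in this assay likewise gives only a limit: > 100000 nM.
Compound 3, `Nc1ccc(-c2cc(=O)c3c(N)c(F)c(C(=O)O)c(F)c3o2)cc1F`, in this assay also gives only a limit: > 100000 nM.

Compound 1 therefore stands at the limit of this assay and at no number. Compound 4, `CCCCCCOCc1c(F)c(N)c2c(=O)cc(-c3ccc(N)c(F)c3)oc2c1F`, differs from it in one place: a group of 8 heavy atoms (7 carbon, 1 oxygen; no ring) in place of a group of 3 heavy atoms (1 carbon, 1 oxygen, 1 sulfur; no ring), on an aromatic carbon. The steps that touch compound 1 are a step that the two limits leave unreadable from compound 1 to compound 2 and a step that the two limits leave unreadable from compound 1 to compound 3, and neither has a readable size, since (the limit of > 100000 nM in this assay, at which 3 of the 3 values shown sit). For the measured compounds named here, no measured step thus points to any direction for the change from compound 1 to compound 4. Compound 4 is expected to give about 100000 nM, between 30000 nM and 300000 nM, most probably again as a limit. The step of a number no higher from compound 1 to compound 4 (the limit leaves the size open) that this estimate means is expected to be no readable step at all.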

Compound 4, half-maximal inhibitory concentration: > 100000 nM
Compound 4 gave a limit, no number; the forecaster's own chance of this, stated with the estimate: 85%; the middle value lies on the limit itself.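

Compound 4, like compound 1, compound 2 and compound 3, gives only a limit, so none of the steps among these four compounds can be read: the limit of > 100000 nM in this assay, at which 4 of the 4 values shown sit.

The compounds shown leave open whether any group at this place on the shared core would give a readable number in this assay.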